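A few compounds are considered here, and "the series" means these few. Any claim that something is new, unique, unknown or untested is made for them only; others in the source may bear on it.

Three compounds of this series have numbers in an assay on CHO cells for displacement of a labelled ligand from prostaglandin E2 receptor EP3 subtype (Homo sapiens), read by radioligand binding; on this read-out lower numbers stand for stronger inhibition and higher numbers for weaker inhibition. Compound 1 `CC(C)C(/C=C1\CCNC1=O)c1ccc(-c2ccc3cccc(F)c3c2)[nH]c1=O` gives 2.2 nM, compound 2 `CCn1ncc2c(C)cc(-c3ccc([C@@]4(C)CCNC4=O)c(=O)[nH]3)cc21` gives 5 nM, and compound 3 `CCC(CC)(c1nnc[nH]1)c1ccc(-c2ccc3cccc(F)c3c2)[nH]c1=O` gives 19 nM. Compound 3 stands at the highest of the three numbers: its nearest neighbour is compound 2, whose number is lower by a margin beyond the scatter, and the gap to compound 1 is wider still, also beyond the scatter.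

The step under consideration goes from compound 3 to compound 4 `CCC(CC)(c1nnc[nH]1)c1ccc(-c2ccc3cc(F)cc(F)c3c2)[nH]c1=O`, which has not yet been measured. The change is fluoro in place of hydrogen on an aromatic carbon.

Among the compounds with values here, no pair of measured compounds differing in one place is available, so there is no direct precedent for the effect of a second fluoro on the fused ring of this core. The change enters one heavy atom and leaves the rest of compound 3 untouched. The expectation is therefore a step of a 1.3-fold lower number from compound 3 to compound 4 (0.10 log units; within the scatter), which is to say no change beyond the scatter, with the direction left open.

On that basis compound 4 is estimated at 15 nM in this assay, with a range from 6 nM to 45 nM.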

Compound 4, inhibition constant: 89 nM
Compound 4: the middle estimate sits 5.9-fold (0.77 log units) below what was measured; measured number above the stated range.
By their numbers in this assay, from the lowest: compound 1; then compound 2; then compound 3; then compound 4.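

In this assay, the series now has its first pair differing in one place, and it gives a 4.7-fold higher number from compound 3 to compound 4 (0.67 log units; beyond the scatter), a step beyond the scatter and towards weaker inhibition. Fluoro in place of hydrogen on this aromatic carbon, meta to a fluoro group, is therefore not a neutral change in the setting of compound 3, even though it enters only one heavy atom and adds no ring, hydrogen-bond donor or hydrogen-bond acceptor. The compounds offer no measurement that would explain a step of this size from so small a change.

From the compounds shown here alone, it remains open whether the loss is specific to fluoro or would also follow other groups on this carbon, such as chloro, methoxy or a nitrile, and whether it depends on the fluoro group already present on the ring. Equally open, going by these compounds, is whether the same change would give a similar step with the other side chain of compound 1, which carries the same fluoro-bearing fused ring system.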